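The source may report more compounds than this note shows. Statements on the series, on what has been measured and on what is new or still open speak of the compounds shown alone.

In an ADME assay on THLE-2 cells (Homo sapiens) for cytotoxicity, read by MTT assay (a higher number here means that more compound is tolerated, a lower number that less compound is tolerated), compound 1 (`COc1ccc(C(=O)C=CNc2cc(-c3ccccc3)nn2-c2ccccc2)cc1`) gives 35200 nM. For the measured compounds named here, compound 2 (`c1ccc(-c2ccnc3c2c(-c2ccccc2)nn3-c2ccccc2)cc1`) gives 34200 nM, within the usual scatter of compound 1, so these two stand level at the top of the three numbers known so far. Compound 3 (`N#Cc1c(-c2ccc(Cl)cc2)nc2c(c(-c3ccccc3)nn2-c2ccccc2)c1-c1ccc(N2CCCCC2)cc1`) gives 12500 nM, a lower number, and its gap to compound 1 lies beyond the scatter. Compound 4 (`O=C(C=CNc1cc(-c2ccccc2)nn1-c1ccccc1)c1cccs1`) has not yet been measured. It carries thiophen-2-yl in place of 4-methoxyphenyl on a carbonyl carbon. Going by the values given here, no measured pair differs in only one place, so the data give no direct guide to this swap. The expected change is none beyond the scatter, and the estimated step is a 1.2-fold lower number from compound 1 to compound 4 (0.07 log units; within the scatter). In this assay the expected value for compound 4 is 30000 nM, with an estimated range from 14000 nM to 60000 nM.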

Compound 4, half-maximal cytotoxic concentration: 19900 nM
Compound 4: the middle estimate sits 1.5-fold (0.18 log units) above what was measured; low and high end bracket the measured number.
By their numbers in this assay, from the lowest: compounds 3, 4, 2 and 1 (each within the scatter of the next, the first and the last beyond it).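

For the compounds shown here, the first comparison that changes one place only puts thiophen-2-yl in place of 4-methoxyphenyl on a carbonyl carbon, and in this assay it gives a 1.8-fold lower number from compound 1 to compound 4 (0.25 log units; within the scatter) for this swap. Compound 1 and compound 4 therefore stand level, so a five-membered aromatic ring with a sulfur atom can take the place of the 4-methoxyphenyl group here without a clear shift in the number. Going by these compounds alone, this is only one swap at one position, so it sets no general rule.

From the compounds shown here alone, whether a longer chain or a phenyl ring carrying a carboxylic acid would also stand level at this carbonyl carbon remains open. Nothing measured here offers an explanation for this result.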